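The source may hold more compounds than are shown below. What is called first, only, known or untested is meant among the compounds shown, and "the series" means these compounds.

Measured so far:
- compound 1, `Cc1ccc(-n2nccn2)c(C(=O)N2C[C@H](C#Cc3cccnc3)CC[C@H]2C)c1`: 28 nM in a functional assay on isolated protein for antagonist activity at Orexin receptor type 2 (Homo sapiens), read by FLIPR and calcium flux; on this read-out higher numbers stand for weaker inhibition and lower numbers for stronger inhibition
- compound 2, `Cc1ccc(-n2nccn2)c(C(=O)N2C[C@H](C#Cc3ccc(CO)nc3)CC[C@H]2C)c1`: "not determined" (no result reported) in this assay
- compound 3, `Cc1ccc(-n2nccn2)c(C(=O)N2C[C@H](C#Cc3cncc(CO)c3)CC[C@H]2C)c1`: "not determined" (no result reported) in this assay

Within the data shown here, compound 3 stands without a number in this assay; compound 2 is the other entry without one, so the only number in this small set belongs to compound 1, which gives 28 nM in this assay. All three share the same core and differ only in the ring on the triple-bonded carbon.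

The next compound, compound 4, `Cc1ccc(-n2nccn2)c(C(=O)N2C[C@H](C#Cc3cnccc3O)CC[C@H]2C)c1`, takes one further step from compound 3: 4-hydroxypyridin-3-yl in place of 5-(hydroxymethyl)pyridin-3-yl on a triple-bonded carbon. Among the measured compounds shown here, since compound 3 has no number, no measured step can anchor this change, and no step within the set shows how swapping one hydroxyl-bearing pyridine for another moves the read-out. The expectation for compound 4 therefore rests on compound 1 alone and its 28 nM in this assay, with a wide allowance either way. Compound 4 is estimated at 60 nM, with a range from 10 nM to 400 nM.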

Compound 4, half-maximal inhibitory concentration: 52 nM
The estimate for compound 4 lay 1.2-fold (0.06 log units) above the measured number; low and high end bracket the measured number.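

In this assay, among these compounds, placing a hydroxy group on an aromatic carbon of the ring carried by the triple bond gives a 1.9-fold higher number from compound 1 to compound 4 (0.27 log units; within the scatter), so this is the first measured change at this position, and it lies within the usual scatter of the assay. On these numbers, the 4-hydroxypyridin-3-yl ring of compound 4 cannot be told apart from the unsubstituted ring of compound 1, while the steps involving compound 2 and compound 3 cannot be read, as neither has a number. Nothing measured here offers an explanation for this result.

From the compounds shown here alone, it remains open whether the 5-(hydroxymethyl)pyridin-3-yl ring of compound 3 would read like the ring of compound 4. It is also unknown how a methoxy group, an amine or a carboxylic acid in place of the hydroxy group would read.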